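A few compounds are considered here, and "the series" means these few. Any claim that something is new, unique, unknown or untested is made for them only; others in the source may bear on it.

Measured so far in this series:

compound 1 `COc1cc(Br)ccc1Nc1cc(NC(=O)Nc2c(Cl)cccc2Cl)ncn1` — 29.1%
compound 2 `CCc1cccc(Nc2cc(NC(=O)Nc3cc(OC)cc(OC)c3)ncn2)c1` — 23%
compound 3 `O=C(Nc1cc(Nc2ccc(F)c(Cl)c2)ncn1)Nc1c(Cl)cccc1Cl` — 39.5%

All three values come from a functional assay on NCI-H520 cells (Homo sapiens) for inhibition, read by MTT assay, with a stated time of 48 h, tested at 10 uM; a higher number here means more inhibition at the concentration tested (going by the name of the read-out), a lower number less inhibition. Compound 2 gives the smallest of the three numbers, but compound 1 sits within the scatter of it, so no order between those two can be read; only compound 3 stands apart, beyond the scatter above compound 2.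

The next compound is compound 4 `CCc1ccc(Nc2cc(NC(=O)Nc3cc(OC)cc(OC)c3)ncn2)cc1`. Its difference from compound 2 is 4-ethylphenyl in place of 3-ethylphenyl on a nitrogen on an aromatic ring. Among the compounds with values here, the one measured step at the same nitrogen, a number 10.4 percentage points higher from compound 1 to compound 3 (beyond the scatter), exchanged one substituted phenyl for another and moved the number by a modest amount; it does not test the shift of a single ethyl from one ring position to another, and no other measured pair bears on that. The two shared cores of compound 2 and compound 4 are otherwise identical, and the exchanged groups count the same atoms with no donors or acceptors on either side.

No step beyond the scatter is therefore expected in this assay . Compound 4 is estimated at 25%, with a range from 10% to 40%. The estimated step of a number 2 percentage points higher from compound 2 to compound 4 (within the scatter) is expected to remain within the scatter.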

Compound 4, a percentage reported as inhibition, at one concentration (the size of the read-out at that concentration, not a potency): 23.5%
For compound 4 the middle estimate is 1.5 percentage points above the measured one; low and high end bracket the measured number.
By their numbers in this assay, from the lowest: compounds 2, 4 and 1 (each within the scatter of the next); then compound 3.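

In this assay, 4-ethylphenyl in place of 3-ethylphenyl on a nitrogen on an aromatic ring gives a number 0.5 percentage points higher from compound 2 to compound 4 (within the scatter), so no order between these two compounds can be read. Within the data shown here, this is the first pair that tests the ring position of a single group at this nitrogen, with the same atoms on both sides, whereas the earlier step at the same nitrogen, a number 10.4 percentage points higher from compound 1 to compound 3 (beyond the scatter), exchanged one differently substituted phenyl for another. A change at this nitrogen therefore does not always produce a readable step: the shift of the ethyl group leaves the number within the scatter in this pair, on the shared core of compound 2, and no available evidence offers an explanation for this result.

Still open, as far as these compounds go, is whether the same lack of a readable step would hold for the ethyl shift on the core of compound 3, which carries a different group on the far side of the urea. Also open, from the compounds shown here alone, is whether a longer chain such as hexyl, an amine or a carboxylic acid in place of the ethyl group on this phenyl ring would move the number beyond the scatter.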